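A few compounds are considered here, and "the series" means these few. Any claim that something is new, unique, unknown or untested is made for them only; others in the source may bear on it.

Results so far in a functional assay on EBC-1 cells (Homo sapiens) for antiproliferative activity, with a stated time of 72 h (a higher number here means a weaker inhibitor, a lower number a stronger inhibitor), are:

compound 1 `Cn1cc(-c2cn3c(Cc4ccc5ncccc5c4)cnc3cc2C(F)(F)F)cn1` gives "not determined" (no result reported) as its entry
compound 2 `OCCn1cc(-c2cc(F)c3ncc(Cc4ccc5ncccc5c4)n3c2)cn1` gives 0.34 nM as its value
compound 3 `O=C(c1ccc(-c2cc(F)c3ncc(Cc4ccc5ncccc5c4)n3c2)cc1F)N1CCC2(COC2)C1` gives 406 nM as its value

Of the two compounds with a number, compound 3 stands highest, which makes it the weaker inhibitor, and its gap to compound 2 lies well beyond the scatter.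

Compound 4 `O=C(NCc1ccccn1)c1ccc(-c2cc(F)c3ncc(Cc4ccc5ncccc5c4)n3c2)cc1F` keeps the rest of compound 3 and changes only the group on a carbonyl carbon, where a ((pyridin-2-yl)methyl)amino group enters. The counted difference is a group of 8 heavy atoms (6 carbon, 2 nitrogen; one six-membered aromatic ring with 1 hetero atom) in place of a group of 8 heavy atoms (6 carbon, 1 nitrogen, 1 oxygen; one four-membered non-aromatic ring with 1 hetero atom, one five-membered non-aromatic ring with 1 hetero atom), on a carbonyl carbon in this exchange.

Among the compounds with values here, no measured pair shows what such an exchange does, so any forecast here is a judgement. Compound 2, with the same core, gives 0.34 nM and so leaves much room downward. A drop beyond the scatter is expected in this assay for this exchange, and the estimated size is a 20-fold lower number from compound 3 to compound 4 (1.31 log units; beyond the scatter) on this scale. Compound 4 is estimated at 20 nM with an expected range from 2 nM to 150 nM in this measurement.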

Compound 4, half-maximal inhibitory concentration: 5550 nM
Compound 4: the middle estimate sits 280-fold (2.44 log units) below what was measured; the whole stated range lies below it.
By their numbers in this assay, from the lowest: compound 2; then compound 3; then compound 4.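

In this assay the group on the carbonyl carbon matters a great deal: replacing it gives a 14-fold higher number from compound 3 to compound 4 (1.14 log units; beyond the scatter), although the group that leaves and the one that enters have the same count of heavy atoms. Heavy-atom count alone therefore does not predict the result at this position, and for this pair the ((pyridin-2-yl)methyl)amino group gives the weaker inhibitor. Nothing measured here explains the loss.

Going by these compounds, the amide hydrogen and the six-membered aromatic ring arrive together in this change, so their separate contributions remain unknown. Also open, on these data alone, is how a benzylamino group, which has the ring without its nitrogen, or a simple dimethylamino group or morpholine on the same carbonyl carbon would behave.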